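The source may report more compounds than this note shows. Statements on the series, on what has been measured and on what is new or still open speak of the compounds shown alone.

Compound 2, `COc1ccc2c(=O)c(/C=C/C(=O)NCc3ccccc3F)coc2c1`, is one of two measured analogues built on a shared core. In a functional assay on A549 cells (Homo sapiens) for inhibition, read by MTT assay, with a stated time of 48 h (on this read-out lower numbers stand for stronger inhibition and higher numbers for weaker inhibition), compound 2 reaches only the assay limit, giving > 100000 nM, so only a bound and no number is known for it (the limit of > 100000 nM in this assay, at which 1 of the 2 values shown sits). Its measured neighbour, compound 1, `COc1ccc2c(=O)c(/C=C/C(=O)Nc3ccccc3)coc2c1`, differs from it in the group on the amide-type nitrogen; in this assay compound 1 gives 51000 nM, and the step of an at least 1.9-fold higher number from compound 1 to compound 2 (0.29 log units; that floor lies within the scatter) carries compound 2 to the limit.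

Compound 3, `COc1ccc2c(=O)c(/C=C/C(=O)Nc3ccccc3Cl)coc2c1`, is not yet measured. It differs from compound 2 by 2-chlorophenyl in place of 2-fluorobenzyl on an amide-type nitrogen. For the measured compounds named here, this change removes the 2-fluorobenzyl group that set compound 2 apart from compound 1 and brings back an aryl group, 2-chlorophenyl, on the amide-type nitrogen, so the only step that bears on it is the one from compound 1 to compound 2, which was itself only a bound within the scatter. Compound 3 is therefore expected to fall back toward the number of compound 1 rather than stay at the limit. Compound 3 is estimated to give 50000 nM in this assay, within a range of 20000 nM to 150000 nM, a step of an at least 2.0-fold lower number from compound 2 to compound 3 (0.30 log units; that floor lies within the scatter) that is expected rather than known.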

Compound 3, half-maximal inhibitory concentration: 29900 nM
Beside the measured number, compound 3's estimate is 1.7-fold (0.22 log units) above it, within the range that was stated.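

In this assay, for the compounds shown here, putting 2-chlorophenyl in place of 2-fluorobenzyl on the amide-type nitrogen gives an at least 3.3-fold lower number from compound 2 to compound 3 (0.52 log units; beyond the scatter), the first step in this small set that lies beyond the scatter, and it shows that a measurable number returns once the 2-fluorobenzyl group is gone. The second comparison concerns the aryl group itself: chloro in place of hydrogen on an aromatic carbon gives a 1.7-fold lower number from compound 1 to compound 3 (0.23 log units; within the scatter), so the phenyl and 2-chlorophenyl amides cannot be told apart here, and the chloro adds no effect that can be read. The larger step remains a floor and not a measured size, because compound 2 reaches only an assay limit: the limit of > 100000 nM in this assay, at which 1 of the 3 values shown sits.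

Since 2-fluorobenzyl differs from phenyl in both the added carbon and the fluoro, the compounds shown cannot assign the loss at compound 2 to either one, and a plain benzyl group or a 2-fluorophenyl group on the amide-type nitrogen would be needed to separate them. On these data alone, it also remains open whether a different group in place of the chloro, such as an amine or a carboxylic acid, would move the number beyond the scatter.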